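The source may report more compounds than this note shows. Statements on the series, on what has been measured and on what is new or still open speak of the compounds shown alone.

The study compares three measured compounds built on a shared core. Compound 1 `Nc1cc(N)c2nc(-c3ccccc3)c(Oc3ccc(Cl)c(Cl)c3)nc2c1` gives 58900 nM in a functional assay on NCI-H322M cells (Homo sapiens) for inhibition, read by sulforhodamine B assay, with a stated time of 48 h; a higher number here means a weaker inhibitor of growth, a lower number a stronger inhibitor of growth; that is the higher of the two numbers shown. Compound 3 `COc1ccc(CNc2nc3cc(N)cc(N)c3nc2-c2ccccc2)cc1` gives 52500 nM in this assay, a value that sits within the scatter of compound 1, so no order between the two can be read. Compound 2 `CCOC(=O)[C@H](CCC(=O)O)NC(=O)c1ccc(Oc2nc3cc(N)cc(N)c3nc2-c2ccccc2)cc1` is reported in this assay only as a limit, < 100000 nM; this is the limit of < 100000 nM in this assay, at which 1 of the 3 values shown sits. The not yet measured compound 4 `Nc1cc(N)c2nc(-c3ccccc3)c(Sc3ccc(Cl)c(Cl)c3)nc2c1` differs from compound 1 in one place: (3,4-dichlorophenyl)sulfanyl in place of 3,4-dichlorophenoxy on an aromatic carbon. For the measured compounds named here, no measured pair shows a step of this kind, and the step of a 1.2-fold lower number from compound 1 to compound 4 (0.07 log units; within the scatter) is therefore expected to stay within the scatter, with no direction favoured. Compound 4 is estimated at 50000 nM in this assay, with an expected range from 20000 nM to 120000 nM.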

Compound 4, concentration for total growth inhibition: 35500 nM
The estimate for compound 4 lay 1.4-fold (0.15 log units) above the measured number; low and high end bracket the measured number.
By their numbers in this assay, from the lowest: compounds 4, 3 and 1 (each within the scatter of the next).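

In this assay, putting (3,4-dichlorophenyl)sulfanyl in place of 3,4-dichlorophenoxy on the aromatic carbon next to the ring nitrogen gives a 1.7-fold lower number from compound 1 to compound 4 (0.22 log units; within the scatter). For the compounds shown here, this is the first step read at this position, and it shows that exchanging the oxygen for sulfur, with the heavy-atom count and the dichlorophenyl ring unchanged, leaves the number within the scatter, so the position accepts either group without a readable difference. Nothing in the data shown accounts for this step.

The compounds shown leave open whether a different group at this carbon, such as an amine in place of the sulfur or a longer chain before the dichlorophenyl ring, would move the number beyond the scatter. They also leave open whether the same exchange behaves alike on a core carrying other groups.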